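A few compounds are considered here, and "the series" means these few. Any claim that something is new, unique, unknown or untested is made for them only; others in the source may bear on it.

Measured so far in an assay on FRT cells for positive allosteric modulation of Cystic fibrosis transmembrane conductance regulator variant N1303K (Homo sapiens), in the presence of a further agent that is not named here; on this read-out higher numbers stand for an effect only at larger amounts of compound and lower numbers for an effect already at smaller amounts:
compound 1 `COc1ccc2[nH]c3c(c2c1)CCNC31CCN(Cc2ccc(Cl)cc2Cl)CC1` — 1800 nM
compound 2 `COc1ccc2[nH]c3c(c2c1)CCNC31CCN(Cc2cc(F)cc(Cl)c2)CC1` — 2500 nM
compound 3 `COc1ccc2[nH]c3c(c2c1)CCNC31CCN(Cc2ccc(F)c(Cl)c2F)CC1` — 4500 nM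

Compound 3 holds the highest number of the three; its gap to compound 2 is within the scatter, its gap to compound 1 is beyond it. The next step leads to compound 4 `COc1ccc2[nH]c3c(c2c1)CCNC31CCN(Cc2ccc(F)c(F)c2)CC1`, with the change (3,4-difluorophenyl in place of 3-chloro-2,4-difluorophenyl on a saturated chain carbon bound to an amine nitrogen in a ring). All three measured steps, a 1.4-fold higher number from compound 1 to compound 2 (0.14 log units; within the scatter), a 2.5-fold higher number from compound 1 to compound 3 (0.40 log units; beyond the scatter) and a 1.8-fold higher number from compound 2 to compound 3 (0.26 log units; within the scatter), concern the halogen pattern on this same phenyl ring and stay small, only one of them beyond the scatter. A small step is therefore expected here too, with direction uncertain; on the numbers, a step of a 1.3-fold lower number from compound 3 to compound 4 (0.11 log units; within the scatter) is estimated. Compound 4 is expected at 3500 nM, between 1500 nM and 9000 nM in this assay.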

Compound 4, half-maximal effective concentration: 11000 nM
Beside the measured number, compound 4's estimate is 3.1-fold (0.50 log units) below it; measured number outside the range, above it.
By their numbers in this assay, from the lowest: compounds 1, 2 and 3 (each within the scatter of the next, the first and the last beyond it); then compound 4.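

Compound 4 is the only one of the four without chlorine on this phenyl ring, and it holds the highest number in this assay. All three steps to it lie beyond the scatter (a 2.4-fold higher number from compound 3 to compound 4 (0.39 log units; beyond the scatter); a 4.4-fold higher number from compound 2 to compound 4 (0.64 log units; beyond the scatter); a 6.1-fold higher number from compound 1 to compound 4 (0.79 log units; beyond the scatter)), so this position separates the compounds more clearly than the earlier chlorine-bearing set did. No evidence on the cause is available.

The step from compound 3 removes chlorine and also changes the fluorine pattern, so the two changes cannot be separated. Going by these compounds, how 3,4-dichlorophenyl, or a nitrile or methoxy group on this phenyl ring, would read remains open.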